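A few compounds are considered here, and "the series" means these few. Any claim that something is new, unique, unknown or untested is made for them only; others in the source may bear on it.

In a functional assay on RPMI-8226 cells (Homo sapiens) for antiproliferative activity, read by radiometric assay, with a stated time of 72 h (on this read-out lower numbers stand for stronger inhibition and higher numbers for weaker inhibition), compound 1 (`Cc1cc(F)ccc1Nc1ncnc2cc(NC(=O)CCCCCCC(=O)NO)sc12`) gives 1950 nM, compound 2 (`CCc1cccc(Nc2ncnc3cc(NC(=O)CCCCCCC(=O)NO)sc23)c1`) gives 1570 nM and compound 3 (`CCc1ccc(Nc2ncnc3cc(NC(=O)CCCCCCC(=O)NO)sc23)cc1`) gives 2540 nM. Compound 1 stands among these numbers without separation from either of the others: a 1.2-fold lower number from compound 1 to compound 2 (0.09 log units; within the scatter) and a 1.3-fold higher number from compound 1 to compound 3 (0.11 log units; within the scatter) both lie within the scatter. The account now turns to compound 4 (`COc1ccc(Nc2ncnc3cc(NC(=O)CCCCCCC(=O)NO)sc23)cc1`), which has 4-methoxyphenyl in place of 4-fluoro-2-methylphenyl on a nitrogen on an aromatic ring, a difference counted as 4-methoxyphenyl in place of 4-fluoro-2-methylphenyl on a nitrogen on an aromatic ring. For the measured compounds named here, the steps that bear on it are the exchanges of this same group, the two above and a 1.6-fold higher number from compound 2 to compound 3 (0.21 log units; within the scatter), which also stays within the scatter. Going by the values given here, none of the measured compounds carries 4-methoxyphenyl, so its added hydrogen-bond acceptor remains untested, and no step beyond the scatter is expected in this assay. Compound 4 is expected at 1900 nM, with an estimated range of 900 nM to 4000 nM. The estimate means an expected 1.0-fold lower number from compound 1 to compound 4 (0.01 log units; within the scatter), with no direction claimed.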

Compound 4, half-maximal inhibitory concentration: 1840 nM
The estimate for compound 4 lay 1.0-fold (0.01 log units) above the measured number, within the range that was stated.
By their numbers in this assay, from the lowest: compounds 2, 4, 1 and 3 (each within the scatter of the next).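

In this assay, 4-methoxyphenyl on this nitrogen brings a hydrogen-bond acceptor that 4-fluoro-2-methylphenyl lacks, yet the result stays within the scatter, with a 1.1-fold lower number from compound 1 to compound 4 (0.03 log units; within the scatter) and a 1.2-fold higher number from compound 2 to compound 4 (0.07 log units; within the scatter). The exchange of ethyl for methoxy on an aromatic carbon gives a 1.4-fold lower number from compound 3 to compound 4 (0.14 log units; within the scatter), also within the scatter, so adding an oxygen-bearing group here leaves all four compounds unseparated. No supporting measurement is available to explain this result.

From the compounds shown here alone, it remains open whether an amine or a carboxylic acid on this phenyl ring would produce a step beyond the scatter. Going by these compounds, it is also open whether the same insensitivity would hold with a longer chain on the amide of the shared core.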